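Swapping isobutyl for cyclopentyl on a biguanide core

The source may hold more compounds than are shown below. What is called first, only, known or untested is meant among the compounds shown, and "the series" means these compounds.

Measured compounds:
Compound 1, `N=C(NC(=N)NC1CCCC1)Nc1ccc(C(F)(F)F)cc1`, gives 2500 nM in a functional assay on A2780 cells (Homo sapiens) for antiproliferative activity, read by MTT assay, with a stated time of 72 h; on this read-out higher numbers stand for weaker inhibition and lower numbers for stronger inhibition.
Compound 2, `CC(C)CNC(=N)NC(=N)Nc1ccc(F)cc1F`, gives 19800 nM in this assay.
Compound 3, `CC(C)CNC(=N)NC(=N)Nc1ccc(C(F)(F)F)cc1`, gives 2100 nM in this assay.

Compound 3 and compound 1 share a core and differ in one place: cyclopentyl in place of isobutyl on an amine nitrogen. This change made the step of a 1.2-fold higher number from compound 3 to compound 1 (0.08 log units; within the scatter), so the two numbers cannot be told apart. Compound 2 carries a different aromatic part; the difference between the two cores is not broken down here. Compound 2 stands far from the other two, with the numbers of compound 1 and compound 3 both well below it.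

Compound 4, `N=C(NC(=N)NC1CCCC1)Nc1ccc(F)cc1F`, has not yet been measured. It differs from compound 2 in the same way: cyclopentyl in place of isobutyl on an amine nitrogen. The place of the change is the same in both pairs. For compound 4 in this assay the step of a 1.1-fold higher number from compound 2 to compound 4 (0.05 log units; within the scatter) is expected, resting on the earlier step of a 1.2-fold higher number from compound 3 to compound 1 (0.08 log units; within the scatter), which stayed inside the scatter. Compound 4 is therefore estimated at 22000 nM, with a range from 9000 nM to 55000 nM.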

Compound 4, half-maximal inhibitory concentration: 14700 nM
Compound 4: middle estimate off by 1.5-fold (0.18 log units), on the high side; low and high end bracket the measured number.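

In this assay, cyclopentyl in place of isobutyl on an amine nitrogen gave a 1.3-fold lower number from compound 2 to compound 4 (0.13 log units; within the scatter), so the numbers of these two compounds cannot be told apart. Set beside the earlier step, the same change left the number within the scatter on both cores, and the two steps do not differ from each other: the same change on two cores in this assay, a 1.2-fold higher number (0.08 log units; within the scatter) from compound 3 to compound 1 and a 1.3-fold lower number (0.13 log units; within the scatter) from compound 2 to compound 4, 1.6-fold (0.21 log units) apart, within the scatter of two such steps Within this small set, the swap can therefore be carried from one core to the other without a visible change in the number, but two cores cannot show that this holds for the whole series, and these results do not explain why the swap makes so little difference.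

The compounds shown leave open whether a longer chain or a chain carrying a carboxylic acid on the same amine nitrogen would also leave the number unchanged. They also leave open whether the swap would behave the same way on a core whose aromatic part carries a nitrile instead of fluorine or trifluoromethyl.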